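Hydroxyamino in place of bis(2-hydroxyethyl)amino on a urea

The source may report more compounds than this note shows. Statements on the series, on what has been measured and on what is new or still open speak of the compounds shown alone.

Values in a functional assay on MCF7 cells (Homo sapiens); on this read-out higher numbers stand for weaker inhibition and lower numbers for stronger inhibition:
- compound 1 `COc1cc(NC(C)CCCNC(=O)NC(CO)(CO)CO)c2ncccc2c1`: 24000 nM
- compound 2 `COc1cc(NC(C)CCCNC(=O)N(CCO)CCO)c2ncccc2c1`: 36000 nM

Compound 2, at 36000 nM, stands level with compound 1, as the two values lie within the scatter of each other. Compound 3 `COc1cc(NC(C)CCCNC(=O)NO)c2ncccc2c1` keeps the shared core and carries hydroxyamino in place of bis(2-hydroxyethyl)amino on a carbonyl carbon. Going by the values given here, only one measured step bears on this change, a 1.5-fold higher number from compound 1 to compound 2 (0.18 log units; within the scatter). That step also exchanges the group on a carbonyl carbon, and it stayed within the scatter. It does not involve hydroxyamino, however, so it is only a loose guide. Only a small shift toward a lower number is therefore expected, with no clear move beyond the scatter. The expected step is a 1.8-fold lower number from compound 2 to compound 3 (0.26 log units; within the scatter). The estimate for compound 3 is 20000 nM, with an estimated range of 6000 nM to 60000 nM.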

Compound 3, half-maximal inhibitory concentration: 44000 nM
Compound 3: the middle estimate sits 2.2-fold (0.34 log units) below what was measured; the measured number falls inside the stated range.
By their numbers in this assay, from the lowest: compounds 1, 2 and 3 (each within the scatter of the next).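

In this assay, hydroxyamino on the carbonyl carbon gives a 1.2-fold higher number from compound 2 to compound 3 (0.09 log units; within the scatter), and hydroxy in place of 2-hydroxy-1,1-bis(hydroxymethyl)ethyl on the amide-type nitrogen gives a 1.8-fold higher number from compound 1 to compound 3 (0.26 log units; within the scatter). The earlier pair compared two larger groups, whereas these steps show that the read-out stays within the scatter even when a group of 7 heavy atoms gives way to one of 2, so across these three compounds the size of this group has no readable effect. No supporting measurement is available to explain this result.

Going by these compounds, all three groups carry at least one hydroxy, so it remains open whether a urea ending in a simple methyl, a carboxylic acid or a primary amine would leave the scatter. On these data alone, it also remains open whether a change elsewhere on the shared core would matter more than this one.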